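Ethyl to phenyl at the growth-inhibition limit

The source may hold more compounds than are shown below. What is called first, only, known or untested is meant among the compounds shown, and "the series" means these compounds.

In a toxicity assay on HUVEC cells (Homo sapiens) for inhibition (on this read-out higher numbers stand for weaker inhibition of growth and lower numbers for stronger inhibition of growth), compound 1 `COC(=O)c1ccsc1NC(=O)[C@@H]1CCCN1` gives > 250 ug/mL, a limit of the assay. Compound 2 `CCOC(=O)c1ccsc1NC(=O)[C@@H]1CCCN1` gives > 250 ug/mL, also a limit. Going by the values given here, the series so far stands at the limit of > 250 ug/mL in this assay, at which 2 of the 2 values shown sit. Compound 3 `O=C(Oc1ccccc1)c1ccsc1NC(=O)[C@@H]1CCCN1` differs from compound 2 by phenyl in place of ethyl on an oxygen next to a carbonyl group. Among the compounds with values here, the only measured step, a step that the two limits leave unreadable from compound 1 to compound 2, offers no size to carry over to this change. In this assay, the expected step is an at least 1.1-fold lower number from compound 2 to compound 3 (0.05 log units; that floor lies within the scatter), with no shift beyond the scatter expected in either direction. Compound 3 is estimated at 220 ug/mL, with an expected range of 70 ug/mL to 500 ug/mL.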

Compound 3, concentration for 50% growth inhibition: > 250 ug/mL
Compound 3 ended at the assay's limit (the forecaster's own chance of this, stated with the estimate: 55%); middle value at least 1.1-fold (0.05 log units) away from the limit.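

In this assay compound 3 gives > 250 ug/mL, a limit of the assay. Its steps from compound 1 and compound 2 cannot be read. The compounds shown leave open whether any group on an oxygen next to a carbonyl group gives a value short of this limit.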